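Trifluoromethyl to chloromethyl: tolerability of compound 4 on Vero cells

The source may report more compounds than this note shows. Statements on the series, on what has been measured and on what is new or still open speak of the compounds shown alone.

Compound 1 `O=C(Nc1ccc(S(=O)(=O)N2CCCC2)cc1)c1ccccc1C(F)(F)F`: in an ADME assay on Vero cells (Chlorocebus sabaeus) for cytotoxicity, read by MTT assay (a higher number here means that more compound is tolerated, a lower number that less compound is tolerated), compound 1 gives > 300000 nM, which is a limit of the assay and not a number.
Compound 2 `O=C(Nc1ccc(S(=O)(=O)N2CCCC2)cc1)c1cccc(C(F)(F)F)c1`: in this assay compound 2 gives > 300000 nM, again a limit.
Compound 3 `O=C(Nc1ccc(S(=O)(=O)N2CCCC2)cc1)c1ccc(C(F)(F)F)cc1`: in this assay compound 3 gives > 300000 nM, again a limit.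

Compound 3 therefore stands at the limit of this assay, and it is not alone there: the limit of > 300000 nM in this assay, at which 3 of the 3 values shown sit. Going by the values given here, no step between measured compounds can be read from these three values, since every one of them is a limit and the positional isomers cannot be ranked against each other.

Compound 4 `O=C(Nc1ccc(S(=O)(=O)N2CCCC2)cc1)c1ccc(CCl)cc1` is the next member to go into this assay. It differs from compound 3 in one place: chloromethyl in place of trifluoromethyl on an aromatic carbon. Among the compounds with values here, no measured step exists for this change, so the expectation rests only on the fact that all three measured compounds sit at the limit. Compound 4 is expected to stay near that limit, with the step of an at least 1.5-fold lower number from compound 3 to compound 4 (0.17 log units; that floor lies within the scatter) estimated as small, and its value is estimated at 200000 nM, in the range 40000 nM to 300000 nM.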

Compound 4, half-maximal cytotoxic concentration: 11000 nM
For compound 4 the middle estimate is 18-fold (1.26 log units) above the measured one; the whole stated range lies above it.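

At the aromatic carbon para to a large group, the trifluoromethyl series gave no sign that the substituent matters, but in this assay chloromethyl in place of trifluoromethyl brings an at least 27-fold lower number from compound 3 to compound 4 (1.43 log units; beyond the scatter). This position is therefore sensitive to the group it carries, at least for this exchange. Compound 4 is the only compound shown with a number rather than a limit, and the others remain at that limit: the limit of > 300000 nM in this assay, at which 3 of the 4 values shown sit.

The compounds shown leave open whether a methyl, hydroxymethyl or bromomethyl group on this carbon would stay at the limit or fall towards compound 4. Also open, as far as these compounds go, is whether chloromethyl would behave the same way at the positions held by trifluoromethyl in compound 1 and compound 2.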